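Carbonyl substituent variation on the piperidine amide series

The source may report more compounds than this note shows. Statements on the series, on what has been measured and on what is new or still open speak of the compounds shown alone.

Compound 1 `Cc1nc(S(C)(=O)=O)ccc1Oc1ncnc(OC2CCN(C(=O)OC(C)F)CC2)c1F` gives 65.5 nM in a functional assay on isolated protein for inhibition of Glucose-dependent insulinotropic receptor (Homo sapiens), read by HTRF and cAMP accumulation (on this read-out higher numbers stand for an effect only at larger amounts of compound and lower numbers for an effect already at smaller amounts), and stands second highest of the three numbers measured. Compound 2 `Cc1nc(S(C)(=O)=O)ccc1Oc1ncnc(OC2CCN(C(=O)SC(C)C)CC2)c1F` gives 6.8 nM and compound 3 `Cc1nc(S(C)(=O)=O)ccc1Oc1ncnc(OC2CCN(C(=O)C(F)(F)F)CC2)c1F` gives 151 nM. The two steps already seen at the carbonyl carbon run in opposite directions: a 9.6-fold lower number from compound 1 to compound 2 (0.98 log units; beyond the scatter), whereas a 2.3-fold higher number from compound 1 to compound 3 (0.36 log units; beyond the scatter). Compound 4 `Cc1nc(S(C)(=O)=O)ccc1Oc1ncnc(OC2CCN(C(=O)c3noc(C(C)(C)F)n3)CC2)c1F` differs from compound 1 as follows: a group of 9 heavy atoms (5 carbon, 2 nitrogen, 1 oxygen, 1 fluorine; one five-membered aromatic ring with 3 hetero atoms) in place of a group of 4 heavy atoms (2 carbon, 1 oxygen, 1 fluorine; no ring), on a carbonyl carbon. Neither measured step brings a ring onto the carbonyl carbon; they fix no direction, but both show that this position shifts the number by a modest amount. A modest step is expected, a 2.6-fold lower number from compound 1 to compound 4 (0.42 log units; beyond the scatter), leaning toward a lower number. Compound 4 is therefore estimated at 25 nM, with a range from 6 nM to 110 nM.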

Compound 4, half-maximal effective concentration: 14 nM
Estimate against measurement, compound 4: 1.8-fold (0.25 log units) above; measured number inside the range.
By their numbers in this assay, from the lowest: compound 2; then compound 4; then compound 1; then compound 3.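

A five-membered aromatic ring with 3 hetero atoms can stand on this carbonyl carbon with the number staying low: the change gives a 4.7-fold lower number from compound 1 to compound 4 (0.67 log units; beyond the scatter) and an 11-fold lower number from compound 3 to compound 4 (1.03 log units; beyond the scatter). The larger group does not displace the isopropylsulfanyl group from the lowest number, as the last step shows: a 2.1-fold higher number from compound 2 to compound 4 (0.31 log units; beyond the scatter). Nothing in hand explains these steps.

Open, on these data alone, is whether the ring or the rest of its group carries the step, and how an amine or a six-membered aromatic ring on the carbonyl carbon would read.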